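Swapping an Oxadiazole for a Nitro Group: Cytotoxicity Outlook

The source may report more compounds than this note shows. Statements on the series, on what has been measured and on what is new or still open speak of the compounds shown alone.

Compound 1, `CC(C)N(Cc1cccc(OCCCCCC(=O)O)c1)C(=O)c1ccccc1`, gives a limit of > 26000 nM.
Compound 2, `Cc1nnc(-c2cccc(-c3ccc(C(=O)N(Cc4cccc(OCCCCCC(=O)O)c4)C(C)C)cc3)c2)o1`, gives a limit of > 26000 nM.

In an ADME assay on Raji cells (Homo sapiens) for cytotoxicity, read by CellTiter-Glo and resazurin assay, with a stated time of 72 h (on this read-out lower numbers stand for an effect already at smaller amounts and higher numbers for an effect only at larger amounts of compound), compound 1 reaches only a limit of the assay, not a number. Going by the values given here, compound 2 stands at the same limit, so the single measured step, a step that the two limits leave unreadable from compound 1 to compound 2, cannot be sized; both values sit at the limit of > 26000 nM in this assay, at which 2 of the 2 values shown sit. Compound 3 is `CC(C)N(Cc1cccc(OCCCCCC(=O)O)c1)C(=O)c1ccc(-c2cccc([N+](=O)[O-])c2)cc1`. It differs from compound 2 by nitro in place of 5-methyl-1,3,4-oxadiazol-2-yl on an aromatic carbon, a smaller group taking the place of the ring. Among the compounds with values here, no measured step with a readable size bears on this change, so no direction can be drawn from the data; the only guidance is that compound 2 showed no effect up to the limit. Compound 3 is therefore expected to behave alike, with an estimated step that the limit leaves unreadable from compound 2 to compound 3. The estimate for compound 3 is 40000 nM, ranging from 15000 nM to 150000 nM.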

Compound 3, half-maximal effective concentration: > 26000 nM
Compound 3 gave a limit, no number; the forecaster's own chance of this, stated with the estimate: 80%; the middle value is on the limit's open side.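

Compound 3 gives only a limit of the assay, > 26000 nM. No step among compound 1, compound 2 and compound 3 can therefore be read: the limit of > 26000 nM in this assay, at which 3 of the 3 values shown sit.

The compounds shown leave open whether 3-nitrophenyl and 3-(5-methyl-1,3,4-oxadiazol-2-yl)phenyl differ in their effect on these cells.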